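The source may hold more compounds than are shown below. What is called first, only, known or untested is meant among the compounds shown, and "the series" means these compounds.

Measured in a functional assay on MDA-MB-231 cells (Homo sapiens) for cytotoxicity, read by MTT assay, with a stated time of 72 h; on this read-out lower numbers stand for stronger inhibition and higher numbers for weaker inhibition:
- compound 1 `Cn1nc(-c2ccccc2)c2cc(C(=N)Nc3cccc(C(F)(F)F)c3)ncc21` gives 21400 nM
- compound 2 `COc1ccc(Cn2nc(-c3ccccc3)c3cc(C(=N)Nc4cccc(C(F)(F)F)c4)ncc32)cc1` gives > 50000 nM (a limit, not a number)

Within the data shown here, compound 1 holds the only true number so far, and it sits in the weak range of this assay. The next compound to read is compound 3 `Cn1ncc2cc(C(=N)Nc3cccc(C(F)(F)F)c3)ncc21`, which carries hydrogen in place of phenyl on an aromatic carbon.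

Among the measured compounds shown here, only one measured step is available: an at least 2.3-fold higher number from compound 1 to compound 2 (0.36 log units; beyond the scatter). Going by these compounds, that step lies at another place, on a saturated chain carbon bound to an aromatic nitrogen, and its true size stays open because one end of it is a limit. It therefore bears on the present change only loosely, as a hint that the series has not gained strength from added bulk or lost it sharply. No phenyl change has been measured, so the expectation is wide. The estimated 1.4-fold higher number from compound 1 to compound 3 (0.15 log units; within the scatter) stays near the scatter, with a slight lean towards a higher number, and a limit reading is quite possible.

For compound 3 the expected value is 30000 nM, with an estimated range of 12000 nM to 50000 nM.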

Compound 3, half-maximal inhibitory concentration: > 50000 nM
Compound 3: a limit, no number; the forecaster's own chance of this, stated with the estimate: 35%; at least 1.6-fold (0.22 log units) between middle value and limit.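

Compound 3 gives > 50000 nM in this assay, which is a limit of the assay and not a number. With hydrogen in place of phenyl on this aromatic carbon, this assay shows an at least 2.3-fold higher number from compound 1 to compound 3 (0.36 log units; beyond the scatter), so this position, and not only the saturated chain carbon bound to an aromatic nitrogen, now has a change that takes compound 1 out of the measurable range. How much of the activity of compound 1 rests on the phenyl stays unsettled because the step has only one true end: the limit of > 50000 nM in this assay, at which 2 of the 3 values shown sit.

Open, going by these compounds, is whether this aromatic carbon needs an aromatic ring at all or only some group larger than hydrogen, a question that a methyl group, a cyclohexyl ring or a pyridine ring at this place would address. Also open, on these data alone, is whether a substituted phenyl, such as 4-fluorophenyl or a phenyl bearing an amine or a carboxylic acid, would give a reading stronger than that of compound 1, which is still weak.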